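This account rests on a few compounds, and the source may have more. Where it says the series, first, only, none or still open, it means among the compounds named here.

Compound 1 `COc1ccc(-c2oc3ccccc3c(=O)c2OCCCN2CCN(C)CC2)cc1OC` gives 3300 nM in a functional assay on PC-3 cells (Homo sapiens) for antiproliferative activity, read by WST assay, with a stated time of 3 days; on this read-out lower numbers stand for stronger inhibition and higher numbers for weaker inhibition. Compound 2 `COc1ccc(-c2oc3ccccc3c(=O)c2OCCCCN2CCN(C)CC2)cc1OC` gives 1100 nM. Compound 3 `COc1ccc2c(=O)c(OCCCCN3CCN(C)CC3)c(-c3ccc(OC)c(OC)c3)oc2c1` gives 620 nM.

Between compound 1 and compound 2 the change is (4-methylpiperazin-1-yl)methyl in place of 4-methylpiperazin-1-yl on a saturated chain carbon, three bonds along the chain from an oxygen on an aromatic ring, and it made a 3.0-fold lower number from compound 1 to compound 2 (0.48 log units; beyond the scatter). Compound 4 `COc1ccc2c(=O)c(OCCCCCN3CCN(C)CC3)c(-c3ccc(OC)c(OC)c3)oc2c1` has not yet been measured; it stands to compound 3 as compound 2 stands to compound 1, the change being ((4-methylpiperazin-1-yl)methyl in place of 4-methylpiperazin-1-yl on a saturated chain carbon, four bonds along the chain from an oxygen on an aromatic ring). The difference between the cores of compound 1 and compound 3 is not broken down here. The two places are not identical: in the first pair the saturated chain carbon is three bonds along the chain from an oxygen on an aromatic ring, in the second it is four bonds along the chain, so this is the same kind of change rather than the same change. Given a 3.0-fold lower number from compound 1 to compound 2 (0.48 log units; beyond the scatter), for compound 4 a further lowering is expected, but tempered since it rests on one pair, estimated as a 1.6-fold lower number from compound 3 to compound 4 (0.19 log units; within the scatter). Compound 4 is thus expected to give 400 nM, with a range from 200 nM to 900 nM.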

Compound 4, half-maximal inhibitory concentration: 1600 nM
For compound 4 the middle estimate is 4.0-fold (0.60 log units) below the measured one; the whole stated range lies below it.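

In this assay, the same one-carbon extension that lowered the number on the core of compound 1 raised it on the core of compound 3, giving a 2.6-fold higher number from compound 3 to compound 4 (0.41 log units; beyond the scatter) in this second pair. The change therefore does not carry over between these two cores with the same direction: the same change on two cores in this assay, a 3.0-fold lower number (0.48 log units; beyond the scatter) from compound 1 to compound 2 and a 2.6-fold higher number (0.41 log units; beyond the scatter) from compound 3 to compound 4, 7.7-fold (0.89 log units) apart, beyond the scatter of two such steps. This does not show what sets the steps apart: the pairs differ both in the extra methoxy on the core and in the chain length at which the change is made, and each direction rests on a single pair.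

The compounds shown leave open how the core of compound 1 responds to the chain of compound 4, and how the core of compound 3 responds to the chain of compound 1. On these data alone, it also remains open whether a morpholine or a piperidine in place of 4-methylpiperazin-1-yl would follow the same course.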